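This account rests on a few compounds, and the source may have more. Where it says the series, first, only, none or still open, it means among the compounds named here.

Measured compounds:
- compound 1, `CCCCCC(=O)c1ccc(OCCCN2CCN(C(=O)CSCC)CC2)cc1`, in an assay on isolated protein for binding affinity to histamine H2 receptor (Homo sapiens) (on this read-out lower numbers stand for stronger inhibition and higher numbers for weaker inhibition), gives 22900 nM
- compound 2, `CCOC(=O)N1CCN(CCCOc2ccc(C(=O)C3CC3)cc2)CC1`, in this assay gives 79400 nM

Compound 2 stands at the higher of the two numbers; compound 1, the nearer of the two, gives a lower number, and the gap between them lies beyond the scatter. Compound 3, `C=C(C)C(=O)c1ccc(OCCCN2CCN(C(=O)OCC)CC2)cc1`, has the same atoms as compound 2 joined differently: 1-methylethenyl in place of cyclopropyl on a carbonyl carbon. Going by the values given here, no pair of measured compounds shows this change, so the size of the step cannot be read from a known example. With nothing to anchor it, the account expects the step from compound 2 to compound 3 to be small, none beyond the scatter, with no direction favoured: a 1.1-fold lower number from compound 2 to compound 3 (0.05 log units; within the scatter). Compound 3 is accordingly estimated at 70000 nM in this assay, within a range from 25000 nM to 200000 nM.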

Compound 3, inhibition constant: 22400 nM
Beside the measured number, compound 3's estimate is 3.1-fold (0.49 log units) above it; the whole stated range lies above it.
By their numbers in this assay, from the lowest: compounds 3 and 1 (each within the scatter of the next); then compound 2.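

In this assay, the group on a carbonyl carbon whose other neighbour is an aromatic carbon proves able to move the number: 1-methylethenyl in place of cyclopropyl, with the same count of heavy atoms but no ring, gives a 3.5-fold lower number from compound 2 to compound 3 (0.55 log units; beyond the scatter). Going by these compounds alone, the earlier compounds offered no pair differing in one place, so this modest step, beyond the scatter, is the first that can be read here. Nothing at hand bears on what lies behind it.

On these data alone, it remains open how isopropyl, the saturated counterpart of 1-methylethenyl, or a longer chain such as pentyl would read at this position when the rest of compound 2 is kept. Also open, as far as these compounds go, is whether the same change would give a step of like size with the other groups of compound 1 in place.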